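The source may hold more compounds than are shown below. What is called first, only, known or untested is meant among the compounds shown, and "the series" means these compounds.

Measured so far in an ADME assay (Rattus norvegicus, strain Wistar Han) for pharmacokinetics; on this read-out higher numbers stand for wider distribution into tissues and lower numbers for narrower distribution:
compound 1 `CCn1c(-c2cnc(C)nc2)nc2c(N[C@H]3CCN(C(=O)C4CC(F)(F)C4)C3)ncnc21` gives 0.9 L/kg;
compound 2 `CCn1c(-c2ccc(C(F)(F)F)nc2)nc2c(O[C@H]3CCN(C(=O)c4cocn4)C3)ncnc21` gives 0.3 L/kg;
compound 3 `CCn1c(-c2ccc(C(F)(F)F)nc2)nc2c(O[C@H]3CCN(C(=O)C4CC4)C3)ncnc21` gives 0.7 L/kg.

Compound 1 has the highest number of the three, though its gap to compound 3 lies within the scatter; only its gap to compound 2 is beyond it. Compound 4 `CCn1c(-c2cnc(C)nc2)nc2c(N[C@H]3CCN(C(=O)C4CCOCC4)C3)ncnc21` differs from compound 1 in one place: oxan-4-yl in place of 3,3-difluorocyclobutyl on a carbonyl carbon. Among the compounds with values here, the one measured step at a carbonyl carbon is a 2.3-fold higher number from compound 2 to compound 3 (0.37 log units; beyond the scatter), where a ring without a hetero atom replaced one with hetero atoms and the number rose. Here the change runs the other way, a ring with one hetero atom entering, so a modest fall in this assay is expected, a 1.5-fold lower number from compound 1 to compound 4 (0.18 log units; within the scatter). Compound 4 is estimated at 0.6 L/kg, between 0.35 L/kg and 1 L/kg.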

Compound 4, volume of distribution: 0.7 L/kg
For compound 4 the middle estimate is 1.2-fold (0.07 log units) below the measured one; measured number inside the range.
By their numbers in this assay, from the lowest: compound 2; then compounds 3, 4 and 1 (each within the scatter of the next).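

In this assay, placing oxan-4-yl on the carbonyl carbon in place of 3,3-difluorocyclobutyl gives a 1.3-fold lower number from compound 1 to compound 4 (0.11 log units; within the scatter), so this exchange of one non-aromatic ring for another, with oxygen entering and both fluorines leaving, shifts the read-out by no more than the usual scatter. That differs in size from a 2.3-fold higher number from compound 2 to compound 3 (0.37 log units; beyond the scatter), a step made on another core with other rings. Nothing shown here gives a cause for this result. Still open, on these data alone, is whether oxan-4-yl behaves the same way on the core of compound 3, and whether an amine or a longer chain at this carbonyl carbon would move the read-out beyond the scatter.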